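The source may report more compounds than this note shows. Statements on the series, on what has been measured and on what is new or still open speak of the compounds shown alone.

In a functional assay on U-87MG ATCC cells for antiproliferative activity against U-87 MG (Homo sapiens), read by MTT assay, with a stated time of 48 h (a higher number here means a weaker inhibitor, a lower number a stronger inhibitor), compound 1 (`Cc1nc(-c2ccc(Cl)cc2)sc1C(=O)CSc1nc(-c2ccccc2)c(C#N)c(=O)[nH]1`) gives 27600 nM as its reading. Among the compounds with values here, compound 2 (`Cc1nc(-c2ccc(Cl)cc2)sc1C(=O)CSc1nc(-c2ccc(Cl)c(Cl)c2)c(C#N)c(=O)[nH]1`) gives 83900 nM in this assay and holds the highest of the two numbers so far, making it the weaker of the pair. Compound 3 (`Cc1nc(-c2ccc(Cl)cc2)sc1C(=O)CSc1nc(-c2cccc(Cl)c2)c(C#N)c(=O)[nH]1`) keeps the shared core and carries 3-chlorophenyl in place of the 3,4-dichlorophenyl of compound 2: hydrogen in place of chloro on an aromatic carbon is hydrogen in place of chloro on an aromatic carbon, ortho to a chloro group and para to a large group. Within the data shown here, only one measured step bears on this: a 3.0-fold higher number from compound 1 to compound 2 (0.48 log units; beyond the scatter) for 3,4-dichlorophenyl in place of phenyl. Compound 3 keeps one of the two chloro groups separating that pair, so a number between compound 1 at 27600 nM and compound 2 at 83900 nM is expected. The expected change is a 1.7-fold lower number from compound 2 to compound 3 (0.24 log units; within the scatter) and is smaller than the step just described, possibly not beyond the scatter. Compound 3 is estimated at 48000 nM (expected range 21000 nM to 110000 nM)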

Compound 3, half-maximal inhibitory concentration: 40100 nM
Beside the measured number, compound 3's estimate is 1.2-fold (0.08 log units) above it; measured number inside the range.
By their numbers in this assay, from the lowest: compounds 1 and 3 (each within the scatter of the next); then compound 2.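

In this assay, removing the chloro group that stands para to a large group gives a 2.1-fold lower number from compound 2 to compound 3 (0.32 log units; beyond the scatter) and shows that this single position on the aryl ring can account for a change beyond the scatter. The chloro group retained in 3-chlorophenyl, set against phenyl, gives a 1.5-fold higher number from compound 1 to compound 3 (0.16 log units; within the scatter) and so does not separate the two compounds, whereas the earlier step showed only the effect of the two chloro groups together. No available evidence accounts for this difference between the two chloro groups.

On these data alone, a chloro group carried only at the position para to a large group is still open, so the contribution of that group alone cannot be read. Also open, as far as these compounds go, is how a methoxy group or an amine on this ring would compare with chloro and hydrogen.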